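This account rests on a few compounds, and the source may have more. Where it says the series, first, only, none or still open, it means among the compounds named here.

Measured so far:
- compound 1, `Cc1ccc2[nH]c(-c3ccc[nH]3)c(C3CC(=O)NC3=O)c2c1`: 4000 nM
- compound 2, `COc1ccc2[nH]c3c(c4c(n5cccc35)C(=O)N(C)C4=O)c2c1`: 40000 nM
- compound 3, `COc1ccc2[nH]c3c(c4c(c5ccnn53)C(=O)NC4=O)c2c1`: 34000 nM

In a functional assay on LoVo cells (Homo sapiens) for cytotoxicity, read by MTT assay, with a stated time of 72 h (on this read-out lower numbers stand for stronger inhibition and higher numbers for weaker inhibition), compound 1 gives the lowest number of the three. Compound 3 gives a higher number in this assay, and compound 2 a higher one still; both gaps to compound 1 lie beyond the scatter. Among the measured compounds shown here, compound 2 and compound 3 are built on a different core from compound 1, so no single-point step connects any pair of the measured compounds.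

Compound 4, `O=C1CC(c2c(-c3ccc[nH]3)[nH]c3ccccc23)C(=O)N1`, differs from compound 1 in one place: hydrogen in place of methyl on an aromatic carbon. The change removes one carbon from the edge of the shared core and leaves every donor and acceptor in place. For the measured compounds named here, no measured step of this kind exists, so the expectation rests on the size of the change alone. A step of this size is expected to stay within the usual scatter, if anything drifting toward a slightly higher number; the estimated step is a 1.3-fold higher number from compound 1 to compound 4 (0.10 log units; within the scatter). For compound 4 the expected value in this assay is 5000 nM, within a range from 2000 nM to 15000 nM.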

Compound 4, half-maximal inhibitory concentration: 8000 nM
Compound 4: middle estimate off by 1.6-fold (0.20 log units), on the low side, within the range that was stated.
By their numbers in this assay, from the lowest: compounds 1 and 4 (each within the scatter of the next); then compounds 3 and 2 (each within the scatter of the next).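

In this assay, among the compounds shown here, hydrogen in place of methyl on an aromatic carbon of the shared core gives a 2.0-fold higher number from compound 1 to compound 4 (0.30 log units; within the scatter) and so provides the first single-point step. For the compounds shown here, compound 1 and compound 4 cannot be told apart on this read-out, so the methyl at this position can be removed without a change that stands clear of the scatter, something the earlier compounds, linked by no step, could not show. No measurement offers an explanation for the size of this step.

With only methyl and hydrogen shown at this aromatic carbon, one step cannot establish how far the position tolerates change. From the compounds shown here alone, whether an ethyl chain, an amine or a carboxylic acid there would move the number beyond the scatter remains open.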